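The source may report more compounds than this note shows. Statements on the series, on what has been measured and on what is new or still open speak of the compounds shown alone.

Measured compounds:
Compound 1, `CCCCCCCC/C=C\CCCCCCCCNC(=O)c1c(C)cccc1C`, gives 9800 nM in an assay on microsomes from intestinal mucosa for inhibition of acyl-CoA:cholesterol acyltransferase (Oryctolagus cuniculus); a lower number here means a stronger inhibitor, a higher number a weaker inhibitor.
Compound 2, `CCCCCCCC/C=C\CCCCCCCCNC(=O)Nc1cc(C)ccc1C`, gives 4500 nM.

Compound 2 holds the lowest of the two numbers; its nearest neighbour is compound 1, and the step of a 2.2-fold lower number from compound 1 to compound 2 (0.34 log units; beyond the scatter) lies beyond the scatter. Compound 3, `CCCCCCCC/C=C\CCCCCCCCNC(=O)Nc1ccc(F)cc1F`, differs from compound 2 by 2,4-difluorophenyl in place of 2,5-dimethylphenyl on an amide-type nitrogen. Among the measured compounds shown here, no measured step changes this ring in the same way; only a 2.2-fold lower number from compound 1 to compound 2 (0.34 log units; beyond the scatter), which alters both the ring and the group on the carbonyl carbon, bears on it loosely, and that step was modest. A step of no change at the digits printed from compound 2 to compound 3 (within the scatter) within the scatter is therefore expected. The estimate for compound 3 is 4500 nM, between 1500 nM and 13000 nM.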

Compound 3, half-maximal inhibitory concentration: 4700 nM
Compound 3: the middle estimate sits 1.0-fold (0.02 log units) below what was measured; low and high end bracket the measured number.
By their numbers in this assay, from the lowest: compounds 2 and 3 (each within the scatter of the next); then compound 1.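

In this assay, 2,4-difluorophenyl in place of 2,5-dimethylphenyl on the amide-type nitrogen gives a 1.0-fold higher number from compound 2 to compound 3 (0.02 log units; within the scatter) and so leaves the number unmoved within the scatter, showing that this position takes fluorine as readily as methyl in these two compounds. The second amino-linked ring also stands apart from the 2,6-dimethylphenyl compound, with a 2.1-fold lower number from compound 1 to compound 3 (0.32 log units; beyond the scatter) as a modest step, so the lower number of compound 2 is not tied to its methyl groups. Nothing at hand explains why the two rings read alike.

Open, as far as these compounds go, is whether a plain phenyl, a methoxy group or a carboxylic acid on this ring would shift the number beyond the scatter. Also open, from the compounds shown here alone, is how a shorter saturated chain would read in place of the long unsaturated one.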